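The compounds below may be only part of what the source reports. "The series", "measured", "known", "first", "only" and "open" are said of these compounds alone.

Measured so far in this series:
compound 1, `Fc1ccc(-c2nn(-c3ccccc3)cc2-c2nc3cc(Cl)ccc3[nH]2)cc1`: 2770 nM
compound 2, `COc1ccc2[nH]c(-c3cn(-c4ccccc4)nc3-c3ccc(F)cc3)nc2c1`: 7510 nM
compound 3, `Fc1ccc2[nH]c(-c3cn(-c4ccccc4)nc3-c3ccc(Cl)cc3)nc2c1`: 2770 nM

All three numbers come from a functional assay on HeLa cells (Homo sapiens) for antiproliferative activity, read by MTT assay, with a stated time of 48 h; a lower number here means a stronger inhibitor, a higher number a weaker inhibitor. In this assay compound 1 gives 2770 nM. Compound 2 gives 7510 nM. Compound 3 gives 2770 nM.

Compound 1 and compound 2 differ in one place: methoxy in place of chloro on an aromatic carbon. That change made a 2.7-fold higher number from compound 1 to compound 2 (0.43 log units; beyond the scatter).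

Compound 3 has the same atoms as compound 1, joined differently; the difference between the two cores is not broken down here. Compound 3 stands level with compound 1 at the digits given, within the scatter. Against compound 2, the number for compound 3 is the lower of the two.

Compound 4, `COc1ccc(-c2nn(-c3ccccc3)cc2-c2nc3cc(F)ccc3[nH]2)cc1`, has not been measured. It differs from compound 3 in one place: methoxy in place of chloro on an aromatic carbon. This is the same kind of change as that from compound 1 to compound 2, not the same change: there the place was on an aromatic carbon of a six-membered aromatic ring of carbon only, part of a fused or bridged system of two rings, meta to a fused ring and para to a fused ring; here it is on an aromatic carbon of a six-membered aromatic ring of carbon only, para to a large group.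

The step from compound 3 to compound 4 is estimated as a 2.0-fold higher number from compound 3 to compound 4 (0.30 log units; within the scatter), to be set beside a 2.7-fold higher number from compound 1 to compound 2 (0.43 log units; beyond the scatter). Within the data shown here, the expectation rests on compound 1 and compound 2 alone, because a 2.7-fold higher number from compound 1 to compound 2 (0.43 log units; beyond the scatter) is the only measured instance of methoxy in place of chloro, and the different surroundings of the place leave the size open, so the range is kept wide. Compound 4 is expected at 5500 nM, between 2500 nM and 12000 nM.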

Compound 4, half-maximal inhibitory concentration: 1740 nM
Beside the measured number, compound 4's estimate is 3.2-fold (0.50 log units) above it, and the stated range ends above it.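

In this assay, the swap of 4-chlorophenyl to 4-methoxyphenyl gives a 1.6-fold lower number from compound 3 to compound 4 (0.20 log units; within the scatter), a step that stays within the scatter, so this pair shows no clear separation between chloro and methoxy at this place. Set against the earlier pair, the same kind of change does not carry over from one core to the other with a fixed size or direction: the same change on two cores in this assay, a 2.7-fold higher number (0.43 log units; beyond the scatter) from compound 1 to compound 2 and a 1.6-fold lower number (0.20 log units; within the scatter) from compound 3 to compound 4, 4.3-fold (0.64 log units) apart, beyond the scatter of two such steps. This shows that the step measured on one pair is a poor guide to the other, but it does not show what sets the two apart, since the pairs differ in the place of the change as well as in the rest of the structure, and two pairs give no general rule for the series.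

Going by these compounds, it remains open whether methoxy in place of chloro would repeat either step on a further core, or at the same place with the other substituents of the core held fixed. Also open, on these data alone, is how a different group at this place on the phenyl ring, such as an amine, a carboxylic acid or a longer alkoxy chain, would read in this assay.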